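A few compounds are considered here, and "the series" means these few. Any claim that something is new, unique, unknown or untested is made for them only; others in the source may bear on it.

Compounds measured in an assay on CHO cells for displacement of a labelled ligand from adenosine receptor A3 (Homo sapiens), tested at 10 uM; on this read-out lower numbers stand for less inhibition and higher numbers for more inhibition at the one concentration tested (going by the name of the read-out):
compound 1 `Nc1ncnc2c1ncn2[C@H]1C[C@H](CO)CO1`: 7%
compound 2 `Nc1ncnc2c1ncn2[C@H]1C[C@@H](CO)CO1`: 31%

Compound 1 gives the lowest of the two numbers in this assay; compound 2 stands a number 24 percentage points higher from compound 1 to compound 2 (beyond the scatter) above it, the two differing only in configuration at one ring carbon (the fact that compounds 1 and 2 differ only in the configuration as drawn). Compound 3 `Nc1ncnc2c1ncn2[C@@H]1OC[C@@H](CO)[C@H]1O` has not yet been measured; it differs from compound 1 by hydroxy in place of hydrogen on a saturated ring carbon. For the measured compounds named here, no measured step involves a hydroxy, so the one known step gives only a loose guide. A modest rise is expected, a number 13 percentage points higher from compound 1 to compound 3 (beyond the scatter), with compound 3 estimated at 20% (range 0% to 50%).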

Compound 3, a percentage reported as inhibition, at one concentration (the size of the read-out at that concentration, not a potency): 7%
Beside the measured number, compound 3's estimate is 13 percentage points above it; the range from low to high includes it.
By their numbers in this assay, from the lowest: compounds 1 and 3 (each within the scatter of the next); then compound 2.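

Hydroxy in place of hydrogen leaves the number in this assay unmoved (no change at the digits printed from compound 1 to compound 3 (within the scatter)), unlike the earlier change of configuration. On this saturated ring carbon, next to the ring atom that bears a hydroxymethyl group, the added hydroxy therefore makes no difference that can be read at the one concentration tested. The only step beyond the scatter remains the earlier one, which involves configuration alone: the fact that compounds 1 and 2 differ only in the configuration as drawn

On these data alone, whether an amine or a methoxy group on the same carbon would move the number stays open. So does whether hydroxy would leave the number unmoved in the configuration of compound 2.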